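Swapping a Pyridin-4-yl Amide Cap for a Benzodioxin Cap

A few compounds are considered here, and "the series" means these few. Any claim that something is new, unique, unknown or untested is made for them only; others in the source may bear on it.

Compound 1 `O=C(NCc1ccccc1C(=O)N[C@H](/C=C(\F)S(=O)(=O)Oc1ccccc1)CCc1ccccc1)c1ccncc1` was tested in a toxicity assay on J774.1 cells (Mus musculus) for cytotoxicity, read by MTT assay, with a stated time of 48 h; on this read-out higher numbers stand for lower toxicity in this test and lower numbers for higher toxicity in this test. In this assay compound 1 gives > 100000 nM, which is a limit of the assay rather than a measured number. A second compound, compound 2 `CC(=O)NCc1ccccc1C(=O)N[C@H](/C=C/S(=O)(=O)c1ccccc1)CCc1ccccc1`, gives 48000 nM in this assay. Compound 1 therefore stands at the upper edge of what the numbers show, because it sits at the limit of > 100000 nM in this assay, at which 1 of the 2 values shown sits, and only a range is known for it. Compound 3 `O=C(NCc1ccccc1C(=O)N[C@H](/C=C(\F)S(=O)(=O)Oc1ccccc1)CCc1ccccc1)c1ccc2c(c1)OCCO2` differs from compound 1 in a single place: 2,3-dihydro-1,4-benzodioxin-6-yl in place of pyridin-4-yl on a carbonyl carbon. Within the data shown here, no step between two measured compounds carries this same change, so the size of its effect has not been observed. Because compound 1 sits at the limit of > 100000 nM in this assay, at which 1 of the 2 values shown sits, any move toward lower toxicity could not be seen; a modest move toward a lower number, near or slightly beyond the scatter, seems the more likely outcome. Compound 3 is expected to give about 70000 nM, with a range from 25000 nM to 200000 nM. The expected step of an at least 1.4-fold lower number from compound 1 to compound 3 (0.15 log units; that floor lies within the scatter) is estimated to be small.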

Compound 3, half-maximal cytotoxic concentration: > 100000 nM
Compound 3 ended at the assay's limit; the forecaster's own chance of this, stated with the estimate: 45%; middle value at least 1.4-fold (0.15 log units) from the limit.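

In this assay, among these compounds, no step from compound 1 to compound 3 can be read, because both compounds sit at a limit rather than at a measured number: the limit of > 100000 nM in this assay, at which 2 of the 3 values shown sit. As far as these compounds go, whether 2,3-dihydro-1,4-benzodioxin-6-yl in place of pyridin-4-yl changes toxicity at all, and in which direction, stays open.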